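One More Aryl Swap on a Shared Core

The compounds below may be only part of what the source reports. "The series", "measured", "known", "first", "only" and "open" are said of these compounds alone.

Three compounds with a shared core differ only in the aromatic group on a ring nitrogen. In an ADME assay on HEK293 cells (Homo sapiens) for cytotoxicity, read by MTT assay, with a stated time of 48 h (a lower number here means a stronger inhibitor, a higher number a weaker inhibitor), compound 1 `C=C1CCC[C@]2(C)CCC(c3cn(-c4ccc(C(C)=O)cc4)nn3)=CC[C@@]12C` gives 520000 nM and compound 2 `C=C1CCC[C@]2(C)CCC(c3cn(-c4cccc([N+](=O)[O-])c4)nn3)=CC[C@@]12C` gives 699000 nM while compound 3 `C=C1CCC[C@]2(C)CCC(c3cn(-c4ccccc4C(C)=O)nn3)=CC[C@@]12C` gives 524000 nM on the same measure. Compound 3 therefore stands level with both neighbours, since its gaps to them lie within the scatter.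

Compound 4 `C=C1CCC[C@]2(C)CCC(c3cn(-c4cccc(OC)c4)nn3)=CC[C@@]12C` has 3-methoxyphenyl in place of the 2-acetylphenyl of compound 3 on an aromatic nitrogen 3-methoxyphenyl in place of 2-acetylphenyl on an aromatic nitrogen and nothing else changes.

Three measured steps swap a group at this same place. These are a 1.0-fold higher number from compound 1 to compound 3 (0.00 log units; within the scatter) and a 1.3-fold lower number from compound 2 to compound 3 (0.13 log units; within the scatter) and a 1.3-fold higher number from compound 1 to compound 2 (0.13 log units; within the scatter) and each stays within the scatter. Among the measured compounds shown here, no measured compound carries 3-methoxyphenyl, so this remains an extrapolation. Even so, no step beyond the scatter is expected in this assay in either direction. The expected step is a 1.1-fold higher number from compound 3 to compound 4 (0.04 log units; within the scatter) and it is a small one. Compound 4 is estimated at 580000 nM with an expected range from 300000 nM to 1000000 nM in this measure.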

Compound 4, half-maximal inhibitory concentration: 734000 nM
Beside the measured number, compound 4's estimate is 1.3-fold (0.10 log units) below it; the range from low to high includes it.
By their numbers in this assay, from the lowest: compounds 1, 3, 2 and 4 (each within the scatter of the next).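

The new group carries neither the acetyl of compound 1 and compound 3 nor the nitro of compound 2, yet in this assay the steps to compound 4 stay within the scatter (a 1.4-fold higher number from compound 3 to compound 4 (0.15 log units; within the scatter); a 1.4-fold higher number from compound 1 to compound 4 (0.15 log units; within the scatter)). The cleanest comparison is methoxy in place of nitro on an aromatic carbon (a 1.1-fold higher number from compound 2 to compound 4 (0.02 log units; within the scatter)), where only the group on the phenyl ring changes, and that step is also within the scatter. All four aryl groups at this place now stand level with one another, so acetyl, nitro and methoxy have yet to produce a step beyond the scatter here. Nothing at hand accounts for this flat picture. Still open, from the compounds shown here alone, is whether a phenyl ring carrying an amine or a carboxylic acid, or a longer alkyl chain in place of the phenyl ring, would stay level too.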